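The compounds below may be only part of what the source reports. "The series", "measured", "known", "first", "only" and "open" are said of these compounds alone.

Compound 1 `CC(C)OC(=O)c1ccc(NCc2cncn2Cc2ccc(-c3ccccc3)cc2)cc1-c1ccccc1` is the reference point of the series. In a toxicity assay on NIH3T3 cells (Mus musculus) for cytotoxicity, read by resazurin assay (a higher number here means that more compound is needed for the effect, a lower number that less compound is needed), compound 1 gives only the limit > 10000 nM, a bound of the assay and not a number, as the limit of > 10000 nM in this assay, at which 1 of the 3 values shown sits, records. Compound 2 `COC(=O)c1ccc(NCc2cncn2Cc2ccc(C(C)(C)C)cc2)cc1-c1ccccc1` carries no result in this assay, "not determined" (no result reported). Compound 3 `COc1ccc(NCc2cncn2Cc2ccc(-c3ccccc3)cc2N)cc1-c1ccccc1` likewise returns only the limit > 1000 nM in this assay, again a bound rather than a number, as the limit of > 1000 nM in this assay, at which 1 of the 3 values shown sits, records. Among the compounds with values here, no two measured compounds differ in a single place, so no measured step is available. Compound 4 `c1ccc(-c2ccc(Cn3cncc3CNc3ccc(-c4cc5ccccc5o4)c(-c4ccccc4)c3)cc2)cc1` arises from compound 1 by one change: 1-benzofuran-2-yl in place of isopropoxycarbonyl on an aromatic carbon. In this assay a step of a number no higher from compound 1 to compound 4 (the limit leaves the size open) is expected, none beyond the scatter, with compound 4 most likely again at a limit. Compound 4 is expected to give about 10000 nM in this assay, within 3000 nM to 30000 nM.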

Compound 4, half-maximal effective concentration: > 10000 nM
Compound 4 gave a limit, no number; the forecaster's own chance of this, stated with the estimate: 70%; the middle value lies on the limit itself.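

Within the data shown here, compound 1 and compound 4 both give only a limit in this assay, not a number, so no step between them can be read. The compounds shown leave open whether 1-benzofuran-2-yl in place of isopropoxycarbonyl changes the value at all.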